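The source may report more compounds than this note shows. Statements on the series, on what has been measured and on what is new or still open speak of the compounds shown alone.

Measured so far:
- compound 1, `O=S(=O)(c1ccc(Br)cc1)c1nc2ccccc2nc1N1CCCC1`: in a functional assay on PC-3 cells (Homo sapiens) for cytotoxicity, read by MTT assay, with a stated time of 72 h (on this read-out higher numbers stand for weaker inhibition and lower numbers for stronger inhibition), compound 1 reaches only the assay limit, > 50000 nM
- compound 2, `Cc1ccc(S(=O)(=O)c2nc3ccccc3nc2N2CCc3ccccc3C2)cc1`: in this assay compound 2 gives 22400 nM

Within the data shown here, compound 2 is the only member of the series with an actual number; the other result is a limit, (the limit of > 50000 nM in this assay, at which 1 of the 2 values shown sits), and compound 1 differs from compound 2 in more than one place, so no step between the two can be read. Compound 3, `O=S(=O)(c1ccc(Br)cc1)c1nc2ccccc2nc1N1CCc2ccccc2C1`, differs from compound 2 by bromo in place of methyl on an aromatic carbon. Among the measured compounds shown here, no measured pair isolates this exchange. The step from compound 2 to compound 3 is expected to be small, a 1.3-fold higher number from compound 2 to compound 3 (0.13 log units; within the scatter), with no direction beyond the scatter supported by the two values shown. Compound 3 is accordingly estimated at 30000 nM, within a range of 10000 nM to 90000 nM, with a fair chance that it too returns only a limit.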

Compound 3, half-maximal inhibitory concentration: > 50000 nM
Compound 3: only a limit was reported; the forecaster's own chance of this, stated with the estimate: 35%; at least 1.6-fold (0.22 log units) between middle value and limit.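

In this assay, among these compounds, the change from 4-methylphenyl to 4-bromophenyl gives the first readable step: an at least 2.2-fold higher number from compound 2 to compound 3 (0.34 log units; beyond the scatter). The result for compound 3 is a limit, > 50000 nM, so this step has a lower bound only and no full size. With 1,2,3,4-tetrahydroisoquinolin-2-yl held in place, only the 4-methylphenyl compound keeps a number, and most of the series now rests at the assay ceiling: the limit of > 50000 nM in this assay, at which 2 of the 3 values shown sit.

The step from compound 1 to compound 3 joins two limits and cannot be read, which leaves the exchange of pyrrolidin-1-yl for 1,2,3,4-tetrahydroisoquinolin-2-yl without a size. As far as these compounds go, it remains open whether 4-methylphenyl paired with pyrrolidin-1-yl would give a number in this assay, and whether a 4-chlorophenyl, a 4-methoxyphenyl or an amine-bearing phenyl on the sulfonyl would give a lower number than compound 2.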